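Two Arylpropanamides Measured, a Pyridyl Analogue Estimated

The source may hold more compounds than are shown below. What is called first, only, known or untested is meant among the compounds shown, and "the series" means these compounds.

Compound 1 `Cc1ccc(-c2ccc(CCC(=O)N3CCCC3)cc2)cc1`: 33200 nM
Compound 2 `O=C(CCCCCCc1ccccn1)N1CCCC1`: > 100000 nM

In an assay on HEK293 cells for inhibition of N-acylethanolamine-hydrolyzing acid amidase (Rattus norvegicus), read by LC-MS, with a stated time of 30 min (on this read-out lower numbers stand for stronger inhibition and higher numbers for weaker inhibition), compound 1 gives 33200 nM, the only number shown. Compound 2 sits at the limit of the limit of > 100000 nM in this assay, at which 1 of the 2 values shown sits, so for compound 2 only a limit is known. Compound 3 `O=C(CCc1ccc(-c2ccccn2)cc1)N1CCCC1` differs from compound 1 by pyridin-2-yl in place of 4-methylphenyl on an aromatic carbon. Going by the values given here, no measured step shows this change, so compound 3 is expected to stay near compound 1 or lose somewhat, a step of a 1.5-fold higher number from compound 1 to compound 3 (0.18 log units; within the scatter) being estimated. Compound 3 is therefore estimated at 50000 nM, within 15000 nM to 200000 nM.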

Compound 3, half-maximal inhibitory concentration: > 100000 nM
Compound 3 gave a limit, no number (the forecaster's own chance of this, stated with the estimate: 30%); middle value at least 2.0-fold (0.30 log units) away from the limit.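

In this assay, going by these compounds alone, pyridin-2-yl in place of 4-methylphenyl gives an at least 3.0-fold higher number from compound 1 to compound 3 (0.47 log units; beyond the scatter), the first measured reading of any change at this position, and it shows that this swap costs inhibition rather than leaving it unchanged. For compound 3, > 100000 nM is a limit and not a number, so the step gives only a lower bound on the loss: the limit of > 100000 nM in this assay, at which 2 of the 3 values shown sit.

The change removes the methyl and adds a ring nitrogen together, and the compounds shown do not separate the two. From the compounds shown here alone, whether a plain phenyl or a pyridin-3-yl group here would stay near compound 1 remains open.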